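Fluoro to Trifluoromethyl, Repeated on a Second Core

This account rests on a few compounds, and the source may have more. Where it says the series, first, only, none or still open, it means among the compounds named here.

Measured so far in a functional assay on HepG2 cells (Homo sapiens) for antiproliferative activity, read by MTT assay, with a stated time of 24 h; a lower number here means a stronger inhibitor, a higher number a weaker inhibitor:
compound 1 `Cc1ccc(-c2nn(-c3ccccc3)cc2-c2nc3ccccc3n2S(=O)(=O)c2ccc(F)cc2)cc1` gives 5060 nM
compound 2 `Cc1ccc(-c2nn(-c3ccccc3)cc2-c2nc3ccccc3n2S(=O)(=O)c2ccc(C(F)(F)F)cc2)cc1` gives 1930 nM
compound 3 `O=S(=O)(c1ccccc1)n1c(-c2cn(-c3ccccc3)nc2-c2ccc(F)cc2)nc2ccccc21` gives 720 nM

Compound 1 and compound 2 differ in one place: trifluoromethyl in place of fluoro on an aromatic carbon. That change produced a 2.6-fold lower number from compound 1 to compound 2 (0.42 log units; beyond the scatter). Compound 3 sits on a different core, and how its core differs from that of compound 1 is not broken down here; it simply shows the lowest number of the three. Compound 4 `O=S(=O)(c1ccccc1)n1c(-c2cn(-c3ccccc3)nc2-c2ccc(C(F)(F)F)cc2)nc2ccccc21` has not yet been measured. It differs from compound 3 by trifluoromethyl in place of fluoro on an aromatic carbon, the same change at the same kind of place as between compound 1 and compound 2. A step of similar size is expected, because the earlier change gave a 2.6-fold lower number from compound 1 to compound 2 (0.42 log units; beyond the scatter), though a single prior example is a thin basis. The expected step is a 2.6-fold lower number from compound 3 to compound 4 (0.41 log units; beyond the scatter). Compound 4 is estimated at 280 nM, with a likely range from 110 nM to 750 nM.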

Compound 4, half-maximal inhibitory concentration: 590 nM
Compound 4: middle estimate off by 2.1-fold (0.32 log units), on the low side; measured number inside the range.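

Carried onto the core of compound 3, the swap from 4-fluorophenyl to 4-(trifluoromethyl)phenyl gave a 1.2-fold lower number from compound 3 to compound 4 (0.09 log units; within the scatter) in this assay, a step too small to separate from repeat-measurement noise. Set beside the earlier step, the new one does not clearly differ from it: the same change on two cores in this assay, a 2.6-fold lower number (0.42 log units; beyond the scatter) from compound 1 to compound 2 and a 1.2-fold lower number (0.09 log units; within the scatter) from compound 3 to compound 4, 2.1-fold (0.33 log units) apart, within the scatter of two such steps. The two steps are therefore compatible with a similar effect on both cores, but they do not show that the effect carries over, and two pairs are too few to establish a rule.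

The compounds shown leave open how other groups at this place on the ring would behave, such as a nitrile, an amine or a carboxylic acid. They also leave open whether the same change would give a similar step on any further core.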